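The compounds below may be only part of what the source reports. "The series", "measured", "known", "first", "only" and "open" are said of these compounds alone.

Measured so far in an assay on isolated protein (Cricetulus griseus) for binding affinity to Alpha-1B adrenergic receptor (Mesocricetus auratus), read by radioligand binding; on this read-out higher numbers stand for weaker inhibition and lower numbers for stronger inhibition:
Compound 1, `Oc1cccc2c1CCCC2c1c[nH]cn1`, gives 145 nM.
Compound 2, `CCS(=O)(=O)Nc1cc(C2CCCCC2)cc2c1CCCC2c1c[nH]cn1`, gives 891 nM.
Compound 3, `CS(=O)(=O)Nc1cccc2c1CCCCC2c1c[nH]cn1`, gives 10000 nM.

Compound 1 has the lowest of the three numbers, which on this read-out means the strongest binding. Compound 2 is the nearest to it, yet its number is higher by more than the usual scatter, and compound 3 lies further away still, also well beyond the scatter. Compound 2 and compound 3 each differ from compound 1 in more than one place, so no single step can be read off from them; they only show that the two measured compounds carrying a sulfonylamino group sit at weaker binding than compound 1.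

The step to follow runs from compound 1 to compound 4, `O=S(=O)(Nc1cccc2c1CCCC2c1c[nH]cn1)C1CC1`, which has not been measured. The change is (cyclopropylsulfonyl)amino in place of hydroxy on an aromatic carbon. The shared core is kept and only the group on that aromatic carbon is exchanged. A step toward a higher number, beyond the scatter, is expected in this assay, because compound 2 gives 891 nM and compound 3 gives 10000 nM while both carry a sulfonylamino group. Compound 4 is therefore estimated at 800 nM, within 200 nM to 4000 nM. For compound 4 the expected step is a 5.5-fold higher number from compound 1 to compound 4 (0.74 log units; beyond the scatter).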

Compound 4, inhibition constant: < 10000 nM
Compound 4 ended at the assay's limit; the forecaster's own chance of this, stated with the estimate: 10%; the middle value does not contradict the limit.
By their numbers in this assay, from the lowest: compound 1; then compound 2; then compound 3.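

In this assay compound 4 gives < 10000 nM, which is a limit of the assay and not a number. No step from compound 1 to compound 4 can be read, because the result for compound 4 is a limit: the limit of < 10000 nM in this assay, at which 1 of the 4 values shown sits.

The compounds shown leave open how strongly compound 4 binds and what exchanging hydroxy for (cyclopropylsulfonyl)amino does to binding on this core.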